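Swapping Bromo for Tert-Butyl on the Phenyl Ring

The compounds below may be only part of what the source reports. "The series", "measured", "known", "first", "only" and "open" are said of these compounds alone.

Compound 1 `OC[C@H]1O[C@@H](n2cnc3c(CSc4c(F)cccc4Cl)ncnc32)[C@H](O)[C@@H]1O` gives 1510 nM in an assay on isolated protein for binding affinity to Equilibrative nucleoside transporter 1 (Homo sapiens); on this read-out lower numbers stand for stronger inhibition and higher numbers for weaker inhibition.
Compound 2 `OC[C@H]1O[C@@H](n2cnc3c(CSc4cccc(I)c4)ncnc32)[C@H](O)[C@@H]1O` gives 245 nM.
Compound 3 `OC[C@H]1O[C@@H](n2cnc3c(CSc4ccc(Br)cc4)ncnc32)[C@H](O)[C@@H]1O` gives 178 nM.

Compound 3 and compound 2 lie within the scatter of each other (a 1.4-fold lower number from compound 2 to compound 3 (0.14 log units; within the scatter)), and both sit clearly apart from compound 1 (an 8.5-fold lower number from compound 1 to compound 3 (0.93 log units; beyond the scatter), a 6.2-fold lower number from compound 1 to compound 2 (0.79 log units; beyond the scatter)). Compound 4 `CC(C)(C)c1ccc(SCc2ncnc3c2ncn3[C@@H]2O[C@H](CO)[C@@H](O)[C@H]2O)cc1` differs from compound 3 by one change: tert-butyl in place of bromo on an aromatic carbon. For the measured compounds named here, none of the measured steps exchanges one group for another at this same place; they only replace the whole aryl pattern, so they bear on the new change loosely and give no clear direction. A small step in this assay is therefore expected, a 1.4-fold higher number from compound 3 to compound 4 (0.15 log units; within the scatter). Compound 4 is estimated at 250 nM, with a range from 60 nM to 1000 nM.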

Compound 4, half-maximal inhibitory concentration: 331000 nM
The estimate for compound 4 lay 1300-fold (3.12 log units) below the measured number, and the stated range ends below it.
By their numbers in this assay, from the lowest: compounds 3 and 2 (each within the scatter of the next); then compound 1; then compound 4.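

In this assay, this position turns out to be far from tolerant: tert-butyl in place of bromo gives a much larger loss than any earlier change of the aryl pattern (with a 1900-fold higher number from compound 3 to compound 4 (3.27 log units; beyond the scatter)). Compound 4 also falls well behind the other two compounds (with a 1400-fold higher number from compound 2 to compound 4 (3.13 log units; beyond the scatter) and a 220-fold higher number from compound 1 to compound 4 (2.34 log units; beyond the scatter)). Even the previously poorest aryl pattern therefore stays far ahead of 4-(tert-butyl)phenyl.

From the compounds shown here alone, whether a methyl, an isopropyl or a methoxy at this place would keep the number low or lose as much remains open. Nothing available explains the size of this loss.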